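This account rests on a few compounds, and the source may have more. Where it says the series, first, only, none or still open, it means among the compounds named here.

The account begins with two measured compounds sharing one core. Compound 1 `COc1ccc(C(=O)N2CCN(c3nc(N)c4cc(OC)c(OC)cc4n3)CC2)cc1OC` carries an amide on the piperazine, and in a functional assay on PC-3 cells (Homo sapiens) for inhibition (on this read-out lower numbers stand for stronger inhibition and higher numbers for weaker inhibition), compound 1 gives 71000 nM. Compound 2 `COc1cc2nc(N3CCN(S(=O)(=O)c4cccc([N+](=O)[O-])c4)CC3)nc(N)c2cc1OC` carries instead a sulfonyl bearing a 3-nitrophenyl group, and in this assay compound 2 gives 32000 nM. Of the two numbers recorded so far, compound 2 holds the lower one, and its gap to compound 1 lies beyond the scatter of repeated measurements, so compound 2 is the stronger inhibitor of the pair.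

The next compound, compound 3 `COc1cc2nc(N3CCN(S(=O)(=O)c4ccc(-c5ccccc5)cc4)CC3)nc(N)c2cc1OC`, is related to compound 2 by a single change: 4-phenylphenyl in place of 3-nitrophenyl on a sulfonyl sulfur. Among the compounds with values here, no measured pair in this set shows the effect of such a change, so there is nothing to copy from. A reasoned expectation is that the step in this assay from compound 2 to compound 3 will be small, if anything toward a lower number, and close to the usual scatter rather than well beyond it. The expected step is a 1.6-fold lower number from compound 2 to compound 3 (0.20 log units; within the scatter). Compound 3 is therefore estimated at 20000 nM in this assay, with a range from 5000 nM to 80000 nM.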

Compound 3, half-maximal inhibitory concentration: 4200 nM
For compound 3 the middle estimate is 4.8-fold (0.68 log units) above the measured one; measured number below the stated range.
By their numbers in this assay, from the lowest: compound 3; then compound 2; then compound 1.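

In this assay, within the data shown here, the group on a sulfonyl sulfur proves able to move the number clearly: 4-phenylphenyl in place of 3-nitrophenyl gives a 7.6-fold lower number from compound 2 to compound 3 (0.88 log units; beyond the scatter), the first single-place step in this set, and it lies beyond the scatter. The change is a composite one, since the entering group brings 2 six-membered aromatic rings of carbon only and no hydrogen-bond acceptors, whereas the leaving group has one such ring and 2 hydrogen-bond acceptors, so this step alone cannot separate the gain of the second ring from the loss of the nitro group. Nothing measured here accounts for the step.

The compounds shown leave open whether the second phenyl ring, the absence of the nitro group or both together go with the lower number, a question that a plain phenyl group on the sulfonyl sulfur would address. They also leave open how an amine, a carboxylic acid or a longer alkyl chain on that sulfur-bound aromatic group would compare with 4-phenylphenyl in this assay, and whether the step would hold on other assays.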